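A few compounds are considered here, and "the series" means these few. Any claim that something is new, unique, unknown or untested is made for them only; others in the source may bear on it.

Compound 1 `C=C(Br)C(=O)Nc1cccc(-c2cn3nc(-c4ccccc4)sc3n2)c1` gives 960 nM in a functional assay on CCRF-CEM cells (Homo sapiens) for inhibition, read by cell counting, with a stated time of 3 days; a higher number here means a weaker inhibitor, a lower number a stronger inhibitor.
Compound 2 `COc1ccc(-c2nn3cc(-c4cccc(N)c4)nc3s2)cc1OC` gives 14000 nM in this assay.
Compound 3 `C=C(Br)C(=O)Nc1cccc(-c2cn3nc(-c4cccc(OC)c4)sc3n2)c1` gives 1200 nM in this assay.

Compounds 1 and 3 share one core and differ in a single place: hydrogen in place of methoxy on an aromatic carbon. That step, a 1.3-fold lower number from compound 3 to compound 1 (0.10 log units; within the scatter), is small, so the two compounds cannot be told apart in this assay. Compound 2 is built on another core, and the difference between the two cores is not broken down here; compound 2 simply stands with the highest number of the three.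

Compound 4 `COc1ccc(-c2nn3cc(-c4cccc(N)c4)nc3s2)cc1` has not yet been measured. It differs from compound 2 in one place: hydrogen in place of methoxy on an aromatic carbon. Around that place the surroundings are not identical to those in compound 3, since here the carbon sits ortho to a methoxy group, so this is the same kind of change rather than the same change. Still, the step from compound 2 to compound 4 is expected to be small, a 1.3-fold lower number from compound 2 to compound 4 (0.10 log units; within the scatter), because the matching change from compound 3 to compound 1 gave a 1.3-fold lower number from compound 3 to compound 1 (0.10 log units; within the scatter). For compound 4 the expected value in this assay is 11000 nM, estimated to lie between 5000 nM and 25000 nM.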

Compound 4, half-maximal inhibitory concentration: >= 250000 nM
Compound 4 gave a limit, no number (the forecaster's own chance of this, stated with the estimate: 5%); middle value at least 22-fold (1.35 log units) from the limit.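

In this assay, swapping the methoxy group for hydrogen gives an at least 17-fold higher number from compound 2 to compound 4 (1.25 log units; beyond the scatter), a large step. Compound 4 gives a limit of the assay and not a number, so this step has a bound rather than an exact size: the limit of >= 250000 nM in this assay, at which 1 of the 4 values shown sits.

Set beside the same swap on the other core, the result does not carry over: the same change on two cores in this assay, a 1.3-fold lower number (0.10 log units; within the scatter) from compound 3 to compound 1 and an at least 17-fold higher number (1.25 log units; beyond the scatter) from compound 2 to compound 4, at least 22-fold (1.34 log units) apart, beyond the scatter of two such steps

So in these two pairs, a change that leaves compound 1 and compound 3 indistinguishable costs a great deal between compound 2 and compound 4, which means the step seen on one core cannot be assumed on the other; two pairs do not show why this happens, nor do they give a rule for any further core.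

On these data alone, it remains open whether the large step comes from the core itself or from the surroundings of the methoxy group that leaves. As far as these compounds go, it is also open how a hydroxyl group, a fluorine atom or an ethoxy group at that place would read.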